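The compounds below may be only part of what the source reports. "The series", "measured", "known", "first", "only" and "open" are said of these compounds alone.

Measured so far:
compound 1, `COc1cc(-c2cc(/C=C/C(=O)c3ccc(N)cc3)[nH]n2)cc(OC)c1OC`, gives 102%
compound 2, `COc1ccc(-c2cc(/C=C/C(=O)c3ccc(N)cc3)[nH]n2)cc1OC`, gives 106%
compound 3, `COc1cc(C(=O)/C=C/c2cc(-c3cc(OC)c(OC)c(OC)c3)n[nH]2)cc(OC)c1OC`, gives 112%

The three measured compounds were tested in a functional assay on MOLT-4 cells (Homo sapiens) for cytotoxicity, read by sulforhodamine B assay, with a stated time of 48 h, tested at 0.1 uM; on this read-out lower numbers stand for a stronger effect and higher numbers for a weaker effect at the one concentration tested. Compound 1, `COc1cc(-c2cc(/C=C/C(=O)c3ccc(N)cc3)[nH]n2)cc(OC)c1OC`, gives 102% in this assay. Compound 2, `COc1ccc(-c2cc(/C=C/C(=O)c3ccc(N)cc3)[nH]n2)cc1OC`, gives 106% in this assay. Compound 3, `COc1cc(C(=O)/C=C/c2cc(-c3cc(OC)c(OC)c(OC)c3)n[nH]2)cc(OC)c1OC`, gives 112% in this assay. All three numbers lie close to one another and within the scatter of each other, so none of them can be told apart from the others on this read-out.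

Compound 2 differs from compound 1 in one place: hydrogen in place of methoxy on an aromatic carbon. The step this change made in this assay is a number 4 percentage points higher from compound 1 to compound 2 (within the scatter). The difference between the core of compound 1 and the core of compound 3 is not broken down here.

Compound 4, `COc1ccc(-c2cc(/C=C/C(=O)c3cc(OC)c(OC)c(OC)c3)[nH]n2)cc1OC`, has not yet been measured in this assay. Compound 4 differs from compound 3 by hydrogen in place of methoxy on an aromatic carbon. Among the measured compounds shown here, this is the same change as the one from compound 1 to compound 2, at a place described in the same words. Because a number 4 percentage points higher from compound 1 to compound 2 (within the scatter) was a step within the scatter, a step of similar size is expected from compound 3 to compound 4, namely a number 2 percentage points lower from compound 3 to compound 4 (within the scatter). On that basis compound 4 is estimated to give 110% in this assay, expected to lie between 98% and 122%.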

Compound 4, a percentage reported as activity, at one concentration (the size of the read-out at that concentration, not a potency): 95%
Compound 4: the middle estimate sits 15 percentage points above what was measured, and the stated range ends above it.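

In this assay, among the compounds shown here, hydrogen in place of methoxy on an aromatic carbon gave a number 17 percentage points lower from compound 3 to compound 4 (beyond the scatter), so the change did not carry over at one size from one core to the other: the same change on two cores in this assay, a number 4 percentage points higher (within the scatter) from compound 1 to compound 2 and a number 17 percentage points lower (beyond the scatter) from compound 3 to compound 4, 21 percentage points apart, beyond the scatter of two such steps This shows that, in these two pairs, the step seen on the core of compound 1 was no guide to the step on the core of compound 3, and that the same change can leave one core within the scatter and move the other beyond it. It does not show why the two steps part or how the change would behave on a further core; the comparison rests on two pairs at one concentration, and compound 4 gives 95% as the size of a read-out at that concentration, not as a potency.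

The compounds shown leave open whether a hydroxyl group, a fluorine atom or a longer alkoxy chain in place of this methoxy would split between the two cores in the same way. They also leave open how compound 3 and compound 4 would compare at any concentration other than the one tested.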